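Trading acetamido for methyl on compound 1

The source may report more compounds than this note shows. Statements on the series, on what has been measured and on what is new or still open speak of the compounds shown alone.

Going by the values given here, in an ADME assay on HEp-2 cells (Homo sapiens) for cytotoxicity (on this read-out higher numbers stand for lower toxicity in this test and lower numbers for higher toxicity in this test), compound 1 (`CC(=O)NCc1ccc2c(c1)nc(Cn1c(=O)n(C(C)C)c3ccccc31)n2CCC(C)C`) gives 178000 nM, the highest of the three numbers measured so far. Compound 2 (`CC(C)CCn1c(Cn2c(=O)n(C(C)C)c3ccccc32)nc2c(CCCN)cccc21`) gives 2340 nM and compound 3 (`C=C(C)n1c(=O)n(Cc2nc3cc(C#N)ccc3n2CCC(C)C)c2ccccc21`) gives 1480 nM, both far lower than the number for compound 1 and well beyond the usual scatter.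

Compound 4 (`CCc1ccc2c(c1)nc(Cn1c(=O)n(C(C)C)c3ccccc31)n2CCC(C)C`) has not yet been measured. It differs from compound 1 in one place: methyl in place of acetamido on a saturated chain carbon bound to an aromatic carbon. This puts methyl in place of acetamido on a saturated chain carbon bound to an aromatic carbon, so acetamidomethyl becomes ethyl. Among the compounds with values here, no measured pair shows this change alone, and compound 2 and compound 3 differ from compound 1 in other ways too, so the forecast is indirect. Even so, compound 2 at 2340 nM and compound 3 at 1480 nM also lack acetamido, which points to a lower number for compound 4.

In this assay, the expected step is large and downward, a 30-fold lower number from compound 1 to compound 4 (1.47 log units; beyond the scatter). For compound 4 the estimated value is 6000 nM, with an expected range from 1500 nM to 40000 nM.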

Compound 4, half-maximal cytotoxic concentration: 18500 nM
Compound 4: the middle estimate sits 3.1-fold (0.49 log units) below what was measured; measured number inside the range.
By their numbers in this assay, from the lowest: compounds 3 and 2 (each within the scatter of the next); then compound 4; then compound 1.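

Going by these compounds alone, this is the first pair in which only one place changes, so the effect of that change can be read directly. In this assay, putting methyl in place of acetamido on a saturated chain carbon bound to an aromatic carbon gives a 9.6-fold lower number from compound 1 to compound 4 (0.98 log units; beyond the scatter), a shift towards higher toxicity in this test that lies beyond the scatter. The group at this place therefore matters to the read-out, although nothing available here explains why the number falls.

This single pair cannot separate the loss of the amide from the loss of heavy atoms, since the two groups differ in both at once. On these data alone, it remains open how a longer chain, an amine or a carboxylic acid at this same place would move the number.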